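A few compounds are considered here, and "the series" means these few. Any claim that something is new, unique, unknown or untested is made for them only; others in the source may bear on it.

Measured so far:
- compound 1 `Nc1scc(CN2CCN(c3ccc(Cl)cc3F)CC2)c1C(=O)c1ccc(Cl)cc1`: 1%
- compound 2 `COc1ccc(N2CCN(Cc3csc(N)c3C(=O)c3ccc(Cl)cc3)CC2)cc1`: 0%
- compound 3 `Nc1scc(CN2CCN(c3ccncc3)CC2)c1C(=O)c1ccc(Cl)cc1`: 2%

All three numbers come from an assay on CHO cells for displacement of a labelled ligand from adenosine receptor A3 (Homo sapiens), read by scintillation counting, with a stated time of 120 min, tested at 10 uM; a lower number here means less inhibition, a higher number more inhibition at the concentration tested (going by the name of the read-out). Compound 3 sits at the top of the three numbers, yet its reading is indistinguishable from the other two: the step of a number 1 percentage points higher from compound 1 to compound 3 (within the scatter) and the step of a number 2 percentage points higher from compound 2 to compound 3 (within the scatter) both lie inside the scatter, as does the step of a number 1 percentage points lower from compound 1 to compound 2 (within the scatter). Every measured step swaps the group on the ring amine nitrogen, and none of them moved the read-out.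

Compound 4 `Nc1scc(CN2CCN(c3cc(F)ccc3F)CC2)c1C(=O)c1ccc(Cl)cc1` continues that pattern of swaps. The change is 2,5-difluorophenyl in place of pyridin-4-yl on an amine nitrogen in a ring. The three measured steps bear directly on it, all being exchanges at the same place, and all were within the scatter. No step beyond the scatter is therefore expected in this assay, in either direction; the estimated step is no change at the digits printed from compound 3 to compound 4 (within the scatter). Compound 4 is expected to give 2%, within a range of -4% to 9%.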

Compound 4, a percentage reported as inhibition, at one concentration (the size of the read-out at that concentration, not a potency): 2%
For compound 4 middle estimate and measured number coincide at the digits printed, within the range that was stated.
By their numbers in this assay, from the lowest: compounds 2, 1, 3 and 4 (each within the scatter of the next).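

In this assay, the exchange of pyridin-4-yl for 2,5-difluorophenyl replaces a ring with a hetero atom and a hydrogen-bond acceptor by a ring of carbon only with no acceptor, and gives no change at the digits printed from compound 3 to compound 4 (within the scatter). Against the two other substituted phenyl groups, the new group gives a number 2 percentage points higher from compound 2 to compound 4 (within the scatter) and a number 1 percentage points higher from compound 1 to compound 4 (within the scatter), so all four groups at this place read alike at the one concentration tested. Nothing measured here offers an explanation for this reading.

As far as these compounds go, all four compounds carry an aromatic ring on this amine nitrogen, so it remains open whether a longer alkyl chain, a carboxylic acid or an amide there would give a step beyond the scatter. From the compounds shown here alone, it also remains open whether a change elsewhere on the shared core would move the number at all.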